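Aroyl series: amino in place of fluoro

The source may report more compounds than this note shows. Statements on the series, on what has been measured and on what is new or still open speak of the compounds shown alone.

Compound 1 `COc1cc(C(=O)c2cn(-c3ccccc3)cc2-c2ccccc2Cl)cc(OC)c1OC`: 76 nM
Compound 2 `COc1cc(C(=O)c2cn(-c3ccc(F)cc3)cc2-c2ccccc2Cl)cc(OC)c1OC`: 83 nM

Both values come from a functional assay on MCF7 cells (Homo sapiens) for cytotoxicity, read by MTT assay, with a stated time of 96 h; on this read-out lower numbers stand for stronger inhibition and higher numbers for weaker inhibition. Compound 2 cannot be separated from compound 1 on these numbers, the measured step being a 1.1-fold higher number from compound 1 to compound 2 (0.04 log units; within the scatter).

Compound 3 `COc1cc(C(=O)c2cn(-c3ccc(N)cc3)cc2-c2ccccc2Cl)cc(OC)c1OC` carries amino in place of fluoro on an aromatic carbon, para to a large group (amino in place of fluoro on an aromatic carbon). The same difference reads 4-fluorophenyl to 4-aminophenyl.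

Going by the values given here, the single measured step bears on this carbon only indirectly, since it exchanges hydrogen for fluoro and no measured compound carries amino. That step stayed within the scatter, so no shift beyond the scatter is expected, and no direction can be argued from two compounds. The range is kept wide for the same lack of data.

The expected step is a 1.2-fold lower number from compound 2 to compound 3 (0.07 log units; within the scatter).

Compound 3 is estimated at 70 nM, with an expected range of 20 nM to 250 nM.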

Compound 3, half-maximal inhibitory concentration: 83 nM
Beside the measured number, compound 3's estimate is 1.2-fold (0.07 log units) below it; low and high end bracket the measured number.
By their numbers in this assay, from the lowest: compounds 1, 2 and 3 (each within the scatter of the next).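

In this assay the exchange of fluoro for amino on the aromatic carbon para to a large group gives no change at the digits printed from compound 2 to compound 3 (within the scatter) and the exchange of hydrogen for amino gives a 1.1-fold higher number from compound 1 to compound 3 (0.04 log units; within the scatter) on the same carbon. Hydrogen, fluoro and amino at this carbon therefore all lie within the scatter of one another, and the hydrogen-bond donor and acceptor counted for amino come with no readable shift in this read-out. No measurement at hand accounts for this flat result.

Still open, on these data alone, is whether a carboxylic acid, a methoxy or an acetamide at this carbon would stay within the same scatter. Also open, as far as these compounds go, is whether the amino exchange reads the same with another group in place of the chloro on the shared core.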